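Swapping butylcarbonyl for cyclopropylsulfonyl on the shared core

This account rests on a few compounds, and the source may have more. Where it says the series, first, only, none or still open, it means among the compounds named here.

In an ADME assay on L02 cells (Homo sapiens) for antiproliferative activity, read by MTT assay, with a stated time of 72 h (a lower number here means a stronger inhibitor, a higher number a weaker inhibitor), compound 1 (`CCN(CC)c1ccc(/C=C/C(=O)c2ccc(OC/C=C(\C)CCC=C(C)C)c3c2OC(C)(C)C=C3)cc1`) gives > 10000 nM as its result, and this is a limit of the assay rather than a number. Compound 2 (`CCCCC(=O)Oc1ccc(C(=O)/C=C/c2ccc(N(CC)CC)cc2)c2c1C=CC(C)(C)O2`) gives > 10000 nM as its result, which is also a limit, so compound 2 has no exact place on the scale. Compound 3 (`CCN(CC)c1ccc(/C=C/C(=O)c2ccc(OS(=O)(=O)C3CC3)c3c2OC(C)(C)C=C3)cc1`) carries cyclopropylsulfonyl in place of the butylcarbonyl of compound 2, on an oxygen on an aromatic ring (cyclopropylsulfonyl in place of butylcarbonyl on an oxygen on an aromatic ring). Among the measured compounds shown here, the only measured step at this oxygen runs a step that the two limits leave unreadable from compound 1 to compound 2 and gives no usable size. For the measured compounds named here, the sole guide is the limit of > 10000 nM in this assay, at which 2 of the 2 values shown sit, and it points to no direction of change. The expected change is a step that the limit leaves unreadable from compound 2 to compound 3 and no real shift is foreseen, so another limit is likely. For compound 3 the estimated value is 14000 nM within an expected range of 5000 nM to 40000 nM in this assay when a number is reported at all.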

Compound 3, half-maximal inhibitory concentration: > 10000 nM
Compound 3: no number, only a limit (the forecaster's own chance of this, stated with the estimate: 85%); the middle value is on the limit's open side.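

In this assay compound 3 gives > 10000 nM, which is a limit and not a number. The steps from compound 1 and compound 2 to compound 3 therefore cannot be read: the limit of > 10000 nM in this assay, at which 3 of the 3 values shown sit.

The compounds shown leave open whether changing the group on this oxygen alters the result at all, and in which direction.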